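The source may report more compounds than this note shows. Statements on the series, on what has been measured and on what is new or still open speak of the compounds shown alone.

Measured so far:
compound 1 `COc1ccc2c(C3CC(c4ccncc4)=NO3)c[nH]c2c1`: 10500 nM
compound 2 `Clc1ccc(Cn2cc(C3CC(c4ccncc4)=NO3)c3ccccc32)cc1`: 25700 nM

In a functional assay on PC-3 cells (Homo sapiens) for inhibition, read by MTT assay, with a stated time of 48 h (on this read-out lower numbers stand for stronger inhibition and higher numbers for weaker inhibition), compound 2 gives the higher of the two numbers, and the gap to compound 1 lies beyond the usual scatter. Compound 3 `COc1ccc2c(C3CC(c4ccncc4)=NO3)cn(Cc3ccc(Cl)cc3)c2c1` differs from compound 2 in one place: methoxy in place of hydrogen on an aromatic carbon. Within the data shown here, no single-change step between measured compounds is available, so the size of this change is not known from the data. Compound 3 is expected to give 16000 nM, within 5000 nM to 50000 nM. The step of a 1.6-fold lower number from compound 2 to compound 3 (0.21 log units; within the scatter) is expected to be small, likely within the scatter.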

Compound 3, half-maximal inhibitory concentration: 95100 nM
The estimate for compound 3 lay 5.9-fold (0.77 log units) below the measured number; measured number above the stated range.
By their numbers in this assay, from the lowest: compound 1; then compound 2; then compound 3.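

In this assay, methoxy in place of hydrogen on this aromatic carbon gives a 3.7-fold higher number from compound 2 to compound 3 (0.57 log units; beyond the scatter), so in the presence of the 4-chlorobenzyl group, this position is sensitive to change and the new group weakens inhibition. With the methoxy already in place, 4-chlorobenzyl in place of hydrogen on the aromatic nitrogen gives a 9.1-fold higher number from compound 1 to compound 3 (0.96 log units; beyond the scatter), also a weakening. No available measurement explains either step.

On these data alone, whether a hydroxyl group or a fluorine atom on the same carbon would weaken inhibition as methoxy does remains open. So does the outcome of a methyl group on the aromatic nitrogen.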